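Triazolyl aniline series: loss of the ring methyl

The compounds below may be only part of what the source reports. "The series", "measured", "known", "first", "only" and "open" are said of these compounds alone.

Measured so far:
compound 1 `Cc1nc(-c2ccccc2NCC2=NCCN2)n(C)n1` gives 0% in a functional assay with Alpha-1D adrenergic receptor (Homo sapiens) as the target, read by calcium flux; a lower number here means a smaller maximal response, a higher number a larger maximal response
compound 2 `CCn1ncnc1-c1ccccc1NCC1=NCCN1` gives 55% in this assay
compound 3 `Cc1n[nH]c(-c2ccccc2NCC2=NCCN2)n1` gives 0% in this assay

Compound 3 stands level with compound 1 at the bottom of the three numbers in this assay; compound 2 lies far above both. Going by the values given here, the one measured step, no change at the digits printed from compound 1 to compound 3 (within the scatter), shows that hydrogen in place of methyl on an aromatic nitrogen left the response unchanged within the scatter. Compound 4 `c1ccc(-c2nc[nH]n2)c(NCC2=NCCN2)c1` carries the change (1H-1,2,4-triazol-3-yl in place of 3-methyl-1H-1,2,4-triazol-5-yl on an aromatic carbon). Among the compounds with values here, no measured step removes a methyl from the triazole carbon, so the expected direction is open; the only precedent, from compound 1 to compound 3, was flat. Compound 4 is therefore estimated at 20% in this assay, within 0% to 60%, implying an expected step of a number 20 percentage points higher from compound 3 to compound 4 (beyond the scatter).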

Compound 4, largest response reached (reported as maximal response), in percent of the reference or control that the assay uses: 123%
Compound 4: middle estimate off by 103 percentage points, on the low side; the measured number lies above the stated range.
By their numbers in this assay, from the lowest: compounds 1 and 3 (each within the scatter of the next); then compound 2; then compound 4.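

In this assay, 1H-1,2,4-triazol-3-yl in place of 3-methyl-1H-1,2,4-triazol-5-yl gives a number 123 percentage points higher from compound 3 to compound 4 (beyond the scatter). A single methyl on the triazole carbon therefore separates a silent compound from the largest response in the series, whereas the earlier change on the aromatic nitrogen gave no change at the digits printed from compound 1 to compound 3 (within the scatter). Nothing at hand accounts for the size of this step.

Open, going by these compounds, is whether the response depends on the methyl specifically or on any group at that carbon; an ethyl, a chlorine or an amine there would test this. Also open, on these data alone, is how a methyl on the aromatic nitrogen behaves when the triazole carbon carries only hydrogen.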